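This account rests on a few compounds, and the source may have more. Where it says the series, first, only, none or still open, it means among the compounds named here.

Compound 1, `COc1ccc(C(c2ccc(OCCO)cc2)c2cccc3ccccc23)c(OC)c1OC`, reaches only a limit in a functional assay on A549 cells (Homo sapiens) for inhibition, read by sulforhodamine B assay, with a stated time of 48 h; on this read-out higher numbers stand for weaker inhibition and lower numbers for stronger inhibition: > 20000 nM.
Compound 2, `COc1ccc(C(c2ccccc2O)c2cccc3ccccc23)c(OC)c1OC`, gives 13600 nM in this assay.
Compound 3, `COc1ccc(C(c2ccc(O)cc2)c2cccc3ccccc23)c(OC)c1OC`, gives 16400 nM in this assay.

Among the two numbers that are not limits, compound 3 stands highest, and its nearest neighbour is compound 2, from which the step of a 1.2-fold higher number from compound 2 to compound 3 (0.08 log units; within the scatter) lies within the usual scatter. The third value, that of compound 1, is a limit of the assay (the limit of > 20000 nM in this assay, at which 1 of the 3 values shown sits), so no number is known for it.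

Compound 4, `COc1ccc(C(c2ccc(OCC(=O)O)cc2)c2cccc3ccccc23)c(OC)c1OC`, differs from compound 3 in a single place: carboxymethyl in place of hydrogen on an oxygen on an aromatic ring. Among the compounds with values here, the one measured step that bears on this position is the change an at least 1.2-fold lower number from compound 1 to compound 3 (0.08 log units; that floor lies within the scatter), in which removing a 2-hydroxyethyl chain from that same oxygen moved the number from a limit to a measurable value, a change whose floor lies within the scatter. Attaching a carboxymethyl chain at the same oxygen is therefore expected to move the number little, perhaps somewhat upward, with a fair chance of again reaching only a limit. For compound 4 the estimate is 20000 nM, between 9000 nM and 45000 nM, which is expected to correspond to the step of a 1.2-fold higher number from compound 3 to compound 4 (0.09 log units; within the scatter).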

Compound 4, half-maximal inhibitory concentration: 16400 nM
Compound 4: middle estimate off by 1.2-fold (0.09 log units), on the high side; the range from low to high includes it.
By their numbers in this assay, from the lowest: compounds 2, 3 and 4 (each within the scatter of the next). At a limit, above all of these: compound 1.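

Within the data shown here, at this oxygen, carboxymethyl in place of hydrogen gives no change at the digits printed from compound 3 to compound 4 (within the scatter) in this assay, so a chain ending in a carboxylic acid can sit here without a measurable shift, which the earlier compounds, none of them carrying an acid, could not show. The acid also stays level with the 2-hydroxyphenyl compound, with a 1.2-fold higher number from compound 2 to compound 4 (0.08 log units; within the scatter), while carboxy in place of hydroxymethyl at the chain end gives an at least 1.2-fold lower number from compound 1 to compound 4 (0.08 log units; that floor lies within the scatter). Compound 1 remains a limit, so the true size of that last step stays unknown: the limit of > 20000 nM in this assay, at which 1 of the 4 values shown sits.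

As far as these compounds go, what remains open is whether any group on this oxygen can move the number beyond the scatter. An amine at the chain end, an amide in place of the acid, or a longer chain could each test this.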